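Pyrazole nitrogen substituent series: toward a pyridylmethyl analogue

A few compounds are considered here, and "the series" means these few. Any claim that something is new, unique, unknown or untested is made for them only; others in the source may bear on it.

Measured so far in a functional assay on MCF7 cells (Homo sapiens) for antiproliferative activity, read by MTT assay, with a stated time of 72 h; on this read-out lower numbers stand for stronger inhibition of growth and higher numbers for weaker inhibition of growth:
compound 1 `Cn1nc(-c2ccnc(Nc3ccc(S(N)(=O)=O)cc3)n2)c2ccccc21` gives 940 nM
compound 2 `CCCn1nc(-c2ccnc(Nc3ccc(S(N)(=O)=O)cc3)n2)c2ccccc21` gives 590 nM

For the measured compounds named here, only two compounds have numbers in this assay. Going by the values given here, compound 2 is one of the pair and its only neighbour is compound 1; the single step between them, a 1.6-fold lower number from compound 1 to compound 2 (0.20 log units; within the scatter), lies within the scatter, so no order between the two can be read from this assay.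

Compound 3 `NS(=O)(=O)c1ccc(Nc2nccc(-c3nn(Cc4cccnc4)c4ccccc34)n2)cc1` is not yet measured. It differs from compound 2 by pyridin-3-yl in place of ethyl on a saturated chain carbon bound to an aromatic nitrogen. Among the compounds with values here, the one measured step that touches the same place, a 1.6-fold lower number from compound 1 to compound 2 (0.20 log units; within the scatter), changed the substituent on that saturated chain carbon without moving the number beyond the scatter. Within the data shown here, no step with a ring entering at this place has been measured, so the present change is larger than anything the two numbers cover, and the expectation rests on that single within-scatter step alone.

For compound 3 the estimate in this assay is 550 nM, with a range of 200 nM to 1500 nM. The step this means, a 1.1-fold lower number from compound 2 to compound 3 (0.03 log units; within the scatter), is expected to stay within the scatter, in no clear direction.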

Compound 3, concentration for 50% growth inhibition: 2630 nM
Compound 3: middle estimate off by 4.8-fold (0.68 log units), on the low side, and the stated range ends below it.
By their numbers in this assay, from the lowest: compounds 2 and 1 (each within the scatter of the next); then compound 3.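

In this assay the saturated chain carbon bound to an aromatic nitrogen proves sensitive to a ring: pyridin-3-yl in place of ethyl gives a 4.5-fold higher number from compound 2 to compound 3 (0.65 log units; beyond the scatter), and pyridin-3-yl in place of hydrogen gives a 2.8-fold higher number from compound 1 to compound 3 (0.45 log units; beyond the scatter). For the compounds shown here, both steps lie beyond the scatter, whereas the only earlier step at this place, between two compounds without a ring in the substituent, stayed within it, so growth inhibition at this position is not indifferent to every substituent, and compound 3 is the weakest of the three while compounds 1 and 2 remain unordered. No supporting measurement accompanies these numbers to account for the shift.

The compounds shown do not separate the contribution of the aromatic ring as such from that of its nitrogen, a question that a benzyl group at this place would address. Also open, on these data alone, are whether the placement of that nitrogen matters, as a (pyridin-4-yl)methyl group would show, and whether a longer chain such as butyl stays level with propyl.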